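Removing the tert-butyl from a weak diaryl alkenyl amino acid

The source may hold more compounds than are shown below. What is called first, only, known or untested is meant among the compounds shown, and "the series" means these compounds.

Measured so far:
compound 1 `CC(C)(C)c1ccc(/C(=C\CC(N)C(=O)O)c2ccc(F)cc2F)cc1` — > 10000 nM
compound 2 `CC(C)c1ccc(/C(=C\CC(N)C(=O)O)c2ccccc2F)cc1` — 8020 nM

Compound 1 has been run in a functional assay for inhibition of sodium- and chloride-dependent glycine transporter 1 (Rattus norvegicus), with a stated time of 30 min, in the presence of a further agent that is not named here (a higher number here means a weaker inhibitor, a lower number a stronger inhibitor), and gives > 10000 nM, which is a limit of the assay and not a number. Compound 1 thus stands at the limit of > 10000 nM in this assay, at which 1 of the 2 values shown sits. Going by the values given here, compound 2 gives 8020 nM in this assay; it differs from compound 1 in more than one place, so the two values show only that both compounds are weak inhibitors.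

Compound 3 `NC(C/C=C(\c1ccccc1)c1ccc(F)cc1F)C(=O)O` differs from compound 1 by hydrogen in place of tert-butyl on an aromatic carbon. Among the compounds with values here, no measured step of this kind exists. Both measured compounds are weak, and the change is expected to leave compound 3 in the same weak region, with no shift beyond the scatter in either direction. The step is expected to be a step that the limit leaves unreadable from compound 1 to compound 3. For compound 3 the estimate is 12000 nM, with a range from 3000 nM to 40000 nM.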

Compound 3, half-maximal inhibitory concentration: 9500 nM
Beside the measured number, compound 3's estimate is 1.3-fold (0.10 log units) above it; the measured number falls inside the stated range.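

In this assay, hydrogen in place of tert-butyl on the aromatic carbon gives an at least 1.0-fold lower number from compound 1 to compound 3 (0.02 log units; that floor lies within the scatter), so this step can be read only as a floor. Compound 1 gives > 10000 nM, which is a limit of the assay and not a number. Compound 3 still gives a measured value, 9500 nM, which shows that the inhibition read at this stage does not depend on the tert-butyl. The true size of the step stays unknown because one end of it is a limit: the limit of > 10000 nM in this assay, at which 1 of the 3 values shown sits.

From the compounds shown here alone, it remains open whether any group at this position, such as an amine, a methoxy group or a carboxylic acid, would move the series out of the weak region. The compounds shown also offer no one-place comparison for the fluorine substituents or for the chain that carries the amino acid.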